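This account rests on a few compounds, and the source may have more. Where it says the series, first, only, none or still open, it means among the compounds named here.

Values in a functional assay on FM3A cells (Mus musculus) for antiproliferative activity, read by cell counting, with a stated time of 2 days (a lower number here means a stronger inhibitor, a higher number a weaker inhibitor), so far:
- Compound 1 `COc1ccc(Nc2nc(N)c(C(=O)c3ccc(Cl)cc3)s2)cc1` gives 59 nM 
- Compound 2 `COc1ccc(Nc2nc(N)c(C(=O)c3cc(OC)c(OC)c(OC)c3)s2)cc1` gives 2200 nM 

Compound 1 has the lower of the two numbers, and the gap to compound 2 lies beyond the scatter. Compound 3 `COc1ccc(Nc2nc(N)c(C(=O)c3ccccc3OC)s2)cc1` keeps the core of compound 1 and carries 2-methoxyphenyl in place of 4-chlorophenyl on a carbonyl carbon. Within the data shown here, no measured step isolates a single change, so the expectation rests on the two values alone. Among the measured compounds shown here, compound 1 (59 nM) is the low reference and compound 2 (2200 nM) is the only higher value available. In this assay the expected change is a rise in the number, beyond the scatter (a 10-fold higher number from compound 1 to compound 3 (1.01 log units; beyond the scatter)). For compound 3 the estimate is 600 nM (expected range 120 nM to 3500 nM).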

Compound 3, half-maximal inhibitory concentration: 52 nM
Compound 3: the middle estimate sits 12-fold (1.06 log units) above what was measured; the measured number lies below the stated range.
By their numbers in this assay, from the lowest: compounds 3 and 1 (each within the scatter of the next); then compound 2.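

Among these compounds, on the carbonyl carbon, putting 2-methoxyphenyl in place of 4-chlorophenyl leaves the number in this assay essentially unchanged, with a 1.1-fold lower number from compound 1 to compound 3 (0.05 log units; within the scatter) as the first single-place step. This shows that the chlorine of compound 1 is not required for a value of this size, and that this position can take a phenyl ring carrying a methoxy group with no change beyond the scatter. No measurement of any property bears on this match, so it remains unexplained.

Still open, as far as these compounds go, is how the position responds to a phenyl ring carrying a carboxylic acid or a dimethylamino group. Among the compounds shown here, also open is what separates compound 2 from compound 1 and compound 3, since no single-place step connects compound 2 to either of them.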